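Chalcone-type series: swapping the carbonyl aryl of compound 1

The compounds below may be only part of what the source reports. "The series", "measured", "known", "first", "only" and "open" are said of these compounds alone.

Three compounds have been run in a functional assay on DU-145 cells (Homo sapiens) for antiproliferative activity, read by MTT assay, with a stated time of 24 h; on this read-out higher numbers stand for weaker inhibition and lower numbers for stronger inhibition. Compound 1 `COc1ccc(-c2cc(/C=C/C(=O)c3cc(OC)c(OC)c(OC)c3)nc3cc(-c4ccccc4)nn23)cc1OC` gives 8300 nM, the lowest of the three numbers; compound 2 `COc1ccc(-c2cc(C(=O)/C=C/c3cc(OC)c(OC)c(OC)c3)nc3cc(-c4ccccc4)nn23)cc1OC` gives 14700 nM and compound 3 `COc1ccc(-c2cc(/C=C/C(=O)c3ccccc3)nc3cc(-c4ccccc4)nn23)cc1` gives 13700 nM, both within the scatter of compound 1, so no order can be read among them. No pair among these three differs in a single place. Compound 4 `COc1ccc(-c2cc(/C=C/C(=O)c3ccc(C)c(C)c3)nc3cc(-c4ccccc4)nn23)cc1OC` is the next to be measured; against compound 1 the difference is 3,4-dimethylphenyl in place of 3,4,5-trimethoxyphenyl on a carbonyl carbon. Within the data shown here, with no step of this kind yet measured, the expectation in this assay is a shift toward weaker inhibition of about a 1.8-fold higher number from compound 1 to compound 4 (0.26 log units; within the scatter), possibly nothing beyond the scatter. Compound 4 is therefore estimated at 15000 nM, within 6000 nM to 40000 nM.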

Compound 4, half-maximal inhibitory concentration: 12100 nM
For compound 4 the middle estimate is 1.2-fold (0.09 log units) above the measured one; low and high end bracket the measured number.
By their numbers in this assay, from the lowest: compounds 1, 4, 3 and 2 (each within the scatter of the next).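

Among these compounds, this is the first single-place step: in this assay, 3,4-dimethylphenyl in place of 3,4,5-trimethoxyphenyl on a carbonyl carbon gives a 1.5-fold higher number from compound 1 to compound 4 (0.16 log units; within the scatter) and so stays within the scatter. At this position, a group with 0 hydrogen-bond acceptors therefore reads the same as one with 3, despite the smaller heavy-atom count. No measurement shown bears on a cause for this step.

Still open, going by these compounds, is whether an amine or a carboxylic acid on this aryl ring would move the number beyond the scatter. Whether a saturated ring such as cyclohexyl could replace the aryl ring on this carbonyl also remains unanswered.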